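The compounds below may be only part of what the source reports. "The series", "measured", "known", "first", "only" and "open" are said of these compounds alone.

Compounds measured so far:

compound 1 `O=C(O)c1ccccc1-c1ccc(CCc2ncc(CCc3ccccc3)[nH]2)cc1` with 1320 nM
compound 2 `CC(C)(C)c1cnc(CCc2ccc(-c3ccccc3C(=O)O)cc2)[nH]1` with 4330 nM

Both were tested in an in vitro functional assay on cells for agonist activity at Bombesin receptor subtype-3 (Homo sapiens), read by luminescence and calcium flux; a lower number here means that less compound is needed, a higher number that more compound is needed for the effect. Compound 2 has the highest of the two numbers recorded there; its nearest neighbour is compound 1, and the step of a 3.3-fold higher number from compound 1 to compound 2 (0.52 log units; beyond the scatter) is modest but beyond the scatter. Compound 3 `O=C(O)c1ccccc1-c1ccc(CCc2ncc(Cc3cccc(F)c3F)[nH]2)cc1` is the next compound to be tested in this assay. It differs from compound 2 in one place: 2,3-difluorobenzyl in place of tert-butyl on an aromatic carbon. For the measured compounds named here, the only measured step that bears on this change is the one from compound 1 to compound 2, where an aromatic-bearing chain gave way to tert-butyl and the number rose. Compound 3 puts an aromatic ring back in that position, though as a 2,3-difluorobenzyl rather than a phenethyl, so a partial return toward the number of compound 1 is expected. For compound 3 the estimate is 1500 nM, with a range from 500 nM to 5000 nM. The expected step of a 2.9-fold lower number from compound 2 to compound 3 (0.46 log units; beyond the scatter) is therefore a modest move toward a lower number.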

Compound 3, half-maximal effective concentration: 87 nM
Compound 3: middle estimate off by 17-fold (1.24 log units), on the high side; the whole stated range lies above it.
By their numbers in this assay, from the lowest: compound 3; then compound 1; then compound 2.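

In this assay, 2,3-difluorobenzyl in place of tert-butyl gives a 50-fold lower number from compound 2 to compound 3 (1.70 log units; beyond the scatter), showing that this position can shift the number much further than the earlier pair had revealed. The new group also goes well past the phenethyl of compound 1, with a 15-fold lower number from compound 1 to compound 3 (1.18 log units; beyond the scatter), so an aromatic ring at this position does more than restore the earlier number, and which aromatic group sits there matters greatly. Nothing available explains this gain.

The compounds shown leave open whether the gain follows the fluorine atoms or the length of the chain, as compound 1 and compound 3 differ in both; a plain benzyl or a 2,3-difluorophenethyl would separate the two. They also leave open how an amine on that aromatic ring would fare.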